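The source may hold more compounds than are shown below. What is called first, only, known or untested is meant among the compounds shown, and "the series" means these compounds.

Half-lives measured in an ADME assay on microsomes from liver (Rattus norvegicus) for metabolic stability, read by LC-MS, using NADPH, at 37 degrees C (a lower number here means that the compound disappears faster, a higher number that the compound lasts longer), are as follows
- compound 1 `Cc1ccccc1-c1nc(CN2CCC(C(=O)NCCCN3CCC(C(C)C)CC3)CC2)c(C)o1` gives 0.147 h
- compound 2 `Cc1oc(-c2ccc(F)cc2)nc1CN1CCC(C(=O)NCCCN2C[C@H](C)C[C@H](C)C2)CC1` gives 0.468 h
- compound 3 `Cc1ccccc1-c1nc(CN2CCC(C(=O)N3CCN(CCN(C)C)CC3)CC2)c(C)o1` gives > 0.5 h as a limit of the assay and not a number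

Compound 2 at 0.468 h holds the higher of the two true numbers, while compound 1 at 0.147 h lies lower by a gap beyond the usual scatter.

Compound 4 `Cc1cccc(-c2nc(CN3CCC(C(=O)NCCCN4C[C@H](C)C[C@H](C)C4)CC3)c(C)o2)c1` carries 3-methylphenyl in place of 4-fluorophenyl on an aromatic carbon and is otherwise the same as compound 2. Going by the values given here, no measured pair isolates this swap. Compound 1 also bears a methyl on its phenyl ring and gives 0.147 h as its half-life, but it differs from compound 2 elsewhere too. Compound 3 bears a methyl on its phenyl ring as well and goes against any simple trend, with its limit > 0.5 h in this assay for that compound.

Only a modest fall is therefore expected, and the estimated change is a 1.6-fold lower number from compound 2 to compound 4 (0.19 log units; within the scatter) within the usual scatter. For compound 4 the estimated half-life is 0.3 h with an expected range from 0.12 h to 0.6 h in this measurement.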

Compound 4, half-life: > 0.5 h
Compound 4: no number, only a limit; the forecaster's own chance of this, stated with the estimate: 15%; middle value at least 1.6-fold (0.22 log units) away from the limit.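

In this assay compound 4 gives > 0.5 h, which is a limit of the assay and not a number. Going by these compounds alone, this is the first pair in which 3-methylphenyl in place of 4-fluorophenyl on an aromatic carbon is the only difference, and it gives an at least 1.0-fold higher number from compound 2 to compound 4 (0.02 log units; that floor lies within the scatter), so in this pair the swap does not shorten the half-life. How much longer compound 4 lasts, if it lasts longer at all, cannot be read because its value sits at the limit of the read-out: the limit of > 0.5 h in this assay, at which 2 of the 4 values shown sit.

From the compounds shown here alone, it therefore stays open whether 3-methylphenyl truly outlasts 4-fluorophenyl on this shared core or merely matches it. Going by these compounds, how an unsubstituted phenyl, a 4-methoxyphenyl or a pyridine ring would behave at this place also remains open.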